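Sulfonylurea series: chain extension on compound 3

The source may report more compounds than this note shows. Statements on the series, on what has been measured and on what is new or still open speak of the compounds shown alone.

Compound 1 `C=CCN(CC)S(=O)(=O)NC(=O)Nc1c(C(C)C)cccc1C(C)C` gives 2100 nM in an assay on liver for inhibition of sterol O-acyltransferase 1 (Rattus norvegicus), using microsomes; a lower number here means a stronger inhibitor, a higher number a weaker inhibitor.
Compound 2 `CC(C)CN(CC(C)C)S(=O)(=O)NC(=O)Nc1c(C(C)C)cccc1C(C)C` gives 420 nM in this assay.
Compound 3 `CCCCCCOS(=O)(=O)NC(=O)Nc1c(C(C)C)cccc1C(C)C` gives 27000 nM in this assay.
Compound 4 `CCCCCCCCCCOS(=O)(=O)NC(=O)Nc1c(C(C)C)cccc1C(C)C` is not yet measured.

In this assay compound 3 stands highest of the three numbers. The steps of a 13-fold higher number from compound 1 to compound 3 (1.11 log units; beyond the scatter) and a 64-fold higher number from compound 2 to compound 3 (1.81 log units; beyond the scatter) both end at compound 3, while the step of a 5.0-fold lower number from compound 1 to compound 2 (0.70 log units; beyond the scatter) lies between the other two compounds. Compound 4 differs from compound 3 by butyl in place of hydrogen on a saturated chain carbon, six bonds along the chain from an oxygen on an unsaturated carbon. For the measured compounds named here, none of the measured steps extends a chain; each exchanges the whole group, so no step bears directly on this change. Compound 4 is therefore expected to give a step of a 1.4-fold lower number from compound 3 to compound 4 (0.13 log units; within the scatter), staying within the scatter. Compound 4 is estimated at 20000 nM, with a range from 5000 nM to 80000 nM.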

Compound 4, half-maximal inhibitory concentration: > 10000 nM
Compound 4 ended at the assay's limit; the forecaster's own chance of this, stated with the estimate: 10%; the middle value does not contradict the limit.
By their numbers in this assay, from the lowest: compound 2; then compound 1; then compound 3.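

Compound 4 gives > 10000 nM in this assay, which is a limit of the assay and not a number, so the step from compound 3 to compound 4 cannot be read. From the compounds shown here alone, whether butyl in place of hydrogen on the chain of compound 3 changes the inhibition remains open.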